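This account rests on a few compounds, and the source may have more. Where it says the series, first, only, none or still open, it means among the compounds named here.

Working notes on the series. The set comprises compound 1 `Cc1c(NC(=O)COc2ccc(/C=C3\SC(=O)NC3=O)cc2)c(=O)n(-c2ccccc2)n1C`, compound 2 `O=C(COc1ccc(/C=C2\SC(=O)NC2=O)cc1)Nc1nc2ccccc2s1` and compound 3 `O=C1NC(=O)/C(=C\c2ccc(OCC(=O)N3C(=O)c4ccccc4S3(=O)=O)cc2)S1`, all examined in a functional assay on Gurav cells (Homo sapiens) for cytotoxicity, read by sulforhodamine B assay, with a stated time of 48 h; on this read-out higher numbers stand for weaker inhibition of growth and lower numbers for stronger inhibition of growth. In this assay compound 1 returns only a limit of the assay, < 100000 nM. For compound 2 the read-out is likewise only a limit of the assay, < 100000 nM. Within the data shown here, compound 3 is the single member with a number, giving 31600 nM in this assay. Compound 2 thus stands together with compound 1 at the limit of < 100000 nM in this assay, at which 2 of the 3 values shown sit, and no ordering of compound 2 against the other two members can be drawn from that. Compound 4 `Cc1cc(NC(=O)COc2ccc(/C=C3\SC(=O)NC3=O)cc2)no1` has not yet been measured in this assay. It differs from compound 2 by 5-methyl-1,2-oxazol-3-yl in place of 1,3-benzothiazol-2-yl on an amide-type nitrogen. Among the measured compounds shown here, no step between measured compounds is available, so there is no measured precedent in this assay for an exchange at this amide-type nitrogen; the expected step in this assay is none beyond the scatter, with no direction assigned. For compound 4 the expected value in this assay is estimated at 40000 nM, with a range from 8000 nM to 100000 nM. The step this estimate means, a step that the limit leaves unreadable from compound 2 to compound 4, is expected to be small and may again end at a limit rather than a number.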

Compound 4, concentration for 50% growth inhibition: 38900 nM
The estimate for compound 4 lay 1.0-fold (0.01 log units) above the measured number; measured number inside the range.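

No step can be read from compound 2 to compound 4 in this assay, because compound 2 carries only a limit of the assay: the limit of < 100000 nM in this assay, at which 2 of the 4 values shown sit.

The compounds shown leave open whether 5-methyl-1,2-oxazol-3-yl in place of 1,3-benzothiazol-2-yl on an amide-type nitrogen changes growth inhibition at all, and in which direction.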